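Replacing the anilide aryl group with a benzyl group

The compounds below may be only part of what the source reports. "The series", "measured", "known", "first", "only" and "open" are said of these compounds alone.

Compound 1 `O=C(Nc1ccc(OC(F)F)cc1)c1cccc(/C=C2\CC(=O)N(c3ccccc3)C2=O)c1` in an ADME assay on NCM460 cells (Homo sapiens) for cytotoxicity, read by MTT assay, with a stated time of 72 h (on this read-out lower numbers stand for stronger inhibition and higher numbers for weaker inhibition), gives > 100000 nM, which is a limit of the assay.
Compound 2 `CCc1cccc(NC(=O)c2cccc(/C=C3\CC(=O)N(c4ccccc4)C3=O)c2)c1` in this assay gives > 100000 nM, which is a limit of the assay.
Compound 3 `COc1ccc(NC(=O)c2cccc(/C=C3\CC(=O)N(c4ccccc4)C3=O)c2)cc1` in this assay gives > 100000 nM, which is a limit of the assay.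

Compound 3 thus stands at the limit of this assay, where every measured value sits (the limit of > 100000 nM in this assay, at which 3 of the 3 values shown sit). The steps a step that the two limits leave unreadable from compound 1 to compound 3 and a step that the two limits leave unreadable from compound 2 to compound 3 cannot be read in size, since both ends are limits. Compound 4 `O=C(NCc1ccccc1)c1cccc(/C=C2\CC(=O)N(c3ccccc3)C2=O)c1` differs from compound 3 by benzyl in place of 4-methoxyphenyl on an amide-type nitrogen. Within the data shown here, no measured step gives a readable size for this change, so compound 4 is expected to remain at the same limit, an expected step of a number no higher from compound 3 to compound 4 (the limit leaves the size open). Compound 4 is estimated at 100000 nM, in a range from 30000 nM to 300000 nM.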

Compound 4, half-maximal inhibitory concentration: > 100000 nM
Compound 4 was reported as a limit (the forecaster's own chance of this, stated with the estimate: 80%); the middle value lies on the limit itself.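

Compound 4 is reported only as a limit, as are compound 1, compound 2 and compound 3, so no step among them can be read in size: the limit of > 100000 nM in this assay, at which 4 of the 4 values shown sit.

The compounds shown leave open whether any group on the amide-type nitrogen would give a measurable value in this assay.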